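An Ester-Bearing Alkene Replaces the Aminomethyl Group

A few compounds are considered here, and "the series" means these few. Any claim that something is new, unique, unknown or untested is made for them only; others in the source may bear on it.

Of the compounds shown here, two sharing one core have been tested in a functional assay with Oryctolagus cuniculus as the target; on this read-out lower numbers stand for stronger inhibition and higher numbers for weaker inhibition. Compound 1 `COc1ccc(-c2nc(CN)sc2-c2ccc(OC)cc2)cc1` carries an aminomethyl group. In this assay compound 1 reaches only a limit, > 100 nM, so no number is known for it. Compound 2 `COc1ccc(-c2nc(C(=O)N3CCNC(CCO)C3)sc2-c2ccc(OC)cc2)cc1` carries a larger amide group instead. In this assay compound 2 also reaches only a limit, > 1000 nM. Going by the values given here, both readings are limits rather than numbers, the limit of > 100 nM in this assay, at which 1 of the 2 values shown sits, and (the limit of > 1000 nM in this assay, at which 1 of the 2 values shown sits), so compound 1 cannot be ranked against compound 2, and no measured step exists between them.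

Compound 3 `CCOC(=O)/C=C/c1nc(-c2ccc(OC)cc2)c(-c2ccc(OC)cc2)s1` is not yet measured. It differs from compound 1 by 2-(ethoxycarbonyl)ethenyl in place of aminomethyl on an aromatic carbon. Among the compounds with values here, with no measured step to lean on, the step is expected to be a step that the limit leaves unreadable from compound 1 to compound 3, in no certain direction. Compound 3 is therefore estimated at 3000 nM, with a range from 300 nM to 30000 nM, and a limit-only result is quite possible.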

Compound 3, half-maximal inhibitory concentration: 20 nM
Beside the measured number, compound 3's estimate is 150-fold (2.18 log units) above it; measured number outside the range, below it.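

Putting 2-(ethoxycarbonyl)ethenyl in place of aminomethyl on this aromatic carbon, next to the ring nitrogen and next to the ring sulfur, gives an at least 5.0-fold lower number from compound 1 to compound 3 (0.69 log units; beyond the scatter) in this assay, a change beyond the usual scatter. Going by these compounds alone, the position therefore accepts a larger chain with no hydrogen-bond donor, and compound 3 is the first compound here to give a number rather than a limit. The true size of the step stays unknown because compound 1 gives only a limit: the limit of > 100 nM in this assay, at which 1 of the 3 values shown sits.

A single compound cannot show whether the ester, the double bond or the chain length matters most for inhibition. A carboxylic acid in place of the ethyl ester, or a saturated chain in place of the ethenyl link, would help to separate these parts.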